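From a Nitrile to a Pyridine on the Amide

A few compounds are considered here, and "the series" means these few. Any claim that something is new, unique, unknown or untested is made for them only; others in the source may bear on it.

Compound 1 `Cc1cccc(C(=O)Nc2c(C(O)(C(F)(F)F)C(F)(F)F)ccc3ccccc23)c1`: 52.5 nM
Compound 2 `N#Cc1cccc(C(=O)Nc2c(C(O)(C(F)(F)F)C(F)(F)F)ccc3ccccc23)c1`: 372 nM

In a functional assay (Sus scrofa) with sulfonylurea receptors; K-ATP channels (Homo sapiens) as the target (on this read-out lower numbers stand for an effect already at smaller amounts and higher numbers for an effect only at larger amounts of compound), compound 2 stands highest of the two numbers shown; the gap to its only neighbour is a 7.1-fold higher number from compound 1 to compound 2 (0.85 log units; beyond the scatter). Compound 3 `O=C(Nc1c(C(O)(C(F)(F)F)C(F)(F)F)ccc2ccccc12)c1cccnc1` differs from compound 2 by pyridin-3-yl in place of 3-cyanophenyl on a carbonyl carbon. For the measured compounds named here, no measured step covers this exchange; the single known step, a 7.1-fold higher number from compound 1 to compound 2 (0.85 log units; beyond the scatter), concerns a different change at that place and so bears on it only loosely. Compound 3 is therefore expected to return part of the way, by an estimated 1.9-fold lower number from compound 2 to compound 3 (0.27 log units; within the scatter). In this assay compound 3 is estimated at 200 nM, within a range from 60 nM to 700 nM.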

Compound 3, half-maximal effective concentration: 617 nM
The estimate for compound 3 lay 3.1-fold (0.49 log units) below the measured number, within the range that was stated.
By their numbers in this assay, from the lowest: compound 1; then compounds 2 and 3 (each within the scatter of the next).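

In this assay pyridin-3-yl in place of 3-cyanophenyl on a carbonyl carbon gives (a 1.7-fold higher number from compound 2 to compound 3 (0.22 log units; within the scatter)), so this exchange does not separate the two groups. Measured against the 3-methylphenyl of compound 1, the same pyridin-3-yl gives (a 12-fold higher number from compound 1 to compound 3 (1.07 log units; beyond the scatter)), which leaves compound 1 apart from both compound 2 and compound 3. Nothing given here explains these numbers.

The compounds shown leave open whether a phenyl ring carrying a methoxy group, a chlorine or an amine at this place would stay close to compound 1 or fall with compound 2 and compound 3.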